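The source may hold more compounds than are shown below. What is called first, only, known or untested is meant among the compounds shown, and "the series" means these compounds.

In a functional assay on L1210 cells (Mus musculus) for cytotoxicity (on this read-out higher numbers stand for weaker inhibition and lower numbers for stronger inhibition), compound 1 (`CCCCCCCCCCCCCCCC(=O)NCC(=O)N[C@@H]1[C@@H](O)[C@H](O)[C@@H](Nc2ncnc3[nH]cnc23)O[C@H]1CO`) reads > 100000 nM as a limit of the assay and not a number. Going by the values given here, compound 2 (`CCCCCC(=O)NCC(=O)N[C@@H]1[C@@H](O)[C@H](O)[C@@H](Nc2ncnc3[nH]cnc23)O[C@H]1C`) gives 250000 nM and so holds the only actual number available, which leaves no measured neighbour to rank it against. Compound 3 (`CCOCCC(=O)NCC(=O)N[C@@H]1[C@@H](O)[C@H](O)[C@@H](Nc2ncnc3[nH]cnc23)O[C@H]1C`) departs from compound 2 by one change (ethoxy in place of propyl on a saturated chain carbon, two bonds along the chain from a carbonyl carbon) with ethoxy in place of propyl on a saturated chain carbon, two bonds along the chain from a carbonyl carbon. Among the compounds with values here, no measured step between related compounds is available as a guide, so no shift beyond the usual scatter is expected in this assay for this swap. The estimate means a 1.1-fold higher number from compound 2 to compound 3 (0.05 log units; within the scatter) as the expected change. Compound 3 is estimated at 280000 nM with an expected range from 120000 nM to 600000 nM in this assay.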

Compound 3, half-maximal inhibitory concentration: > 500000 nM
Compound 3 ended at the assay's limit (the forecaster's own chance of this, stated with the estimate: 35%); middle value at least 1.7-fold (0.25 log units) away from the limit.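

Going by these compounds alone, this is the first step that can be read at this place: ethoxy in place of propyl, on a saturated chain carbon, two bonds along the chain from a carbonyl carbon, gives an at least 2.0-fold higher number from compound 2 to compound 3 (0.30 log units; that floor lies within the scatter) in this assay. The change brings in one oxygen and one hydrogen-bond acceptor at an unchanged count of heavy atoms, and it gives no sign of stronger inhibition at this place. Compound 3 reads as a limit of the assay and not a number, so the step is known only as a floor: the limit of > 500000 nM in this assay, at which 1 of the 3 values shown sits.

On these data alone, whether the true shift from propyl to ethoxy goes beyond the usual scatter stays open. Also open, as far as these compounds go, is how an amine or a carboxylic acid would read at this same place in this assay.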